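One Added Methoxy on Compound 1

The source may hold more compounds than are shown below. What is called first, only, known or untested is meant among the compounds shown, and "the series" means these compounds.

Measured so far in a functional assay on the whole organism (strain Kunming) with Mus musculus as the target, with a stated time of 0.5 h (a lower number here means that less compound is needed, a higher number that more compound is needed for the effect), as dose for half-maximal effect:
Compound 1 `COc1cc(OC)c(OC)cc1/C=C/COC(=O)/C=C/c1ccc(OC)c(OC)c1` gives 58.1 mg/kg 
Compound 2 `COc1cc(OC)c(OC)cc1/C=C/COC(=O)/C=C/c1ccccc1C(F)(F)F` gives 85.7 mg/kg 
Compound 3 `COc1cc(OC)c(OC)cc1/C=C/COC(=O)/C=C/c1cccc(Br)c1` gives 75.7 mg/kg 

Compound 1 stands within the scatter of both compound 2 and compound 3. Compound 4 `COc1cc(OC)c(OC)cc1/C=C/COC(=O)/C=C/c1ccc(OC)c(OC)c1OC` differs from compound 1 by methoxy in place of hydrogen on an aromatic carbon, ortho to a large group, ortho to a methoxy group and meta to a methoxy group (methoxy in place of hydrogen on an aromatic carbon). Among the measured compounds shown here, no measured step adds a methoxy alone. Only the swaps of the 3,4-dimethoxyphenyl group bear on it, and both stay small (a 1.5-fold higher number from compound 1 to compound 2 (0.17 log units; within the scatter); a 1.3-fold higher number from compound 1 to compound 3 (0.11 log units; within the scatter)). No step beyond the scatter is therefore expected in this assay, and the expected step is (a 1.0-fold higher number from compound 1 to compound 4 (0.01 log units; within the scatter)). For compound 4 the estimated value is 60 mg/kg with an expected range from 35 mg/kg to 100 mg/kg around it.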

Compound 4, dose for half-maximal effect: 33.4 mg/kg
The estimate for compound 4 lay 1.8-fold (0.25 log units) above the measured number; measured number below the stated range.
By their numbers in this assay, from the lowest: compounds 4, 1, 3 and 2 (each within the scatter of the next, the first and the last beyond it).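

In this assay, methoxy in place of hydrogen on this aromatic carbon, ortho to a large group, ortho to a methoxy group and meta to a methoxy group, gives a 1.7-fold lower number from compound 1 to compound 4 (0.24 log units; within the scatter). The earlier compounds shown here replaced the whole 3,4-dimethoxyphenyl group, whereas this step keeps it and changes this one position, and the number stays within the scatter. No available evidence bears on the reason for this result. The compounds shown leave open how a hydroxyl, an amine or a longer ether chain would behave at this position.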